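A few compounds are considered here, and "the series" means these few. Any claim that something is new, unique, unknown or untested is made for them only; others in the source may bear on it.

Compound 2 `C=CC(=C)[C@@H](C[C@H]1C(=C)CC[C@H]2[C@](C)(CO)CCC[C@]12C)OO` belongs to a small set of three related structures tested in a functional assay on PC-3 cells (Homo sapiens) for inhibition, read by colorimetric assay and MTT assay; a lower number here means a stronger inhibitor of growth, a higher number a weaker inhibitor of growth. Compound 2 gives 34400 nM, compound 1 `C=C/C(C)=C/C[C@H]1C(=C)CC[C@H]2[C@](C)(CO)CCC[C@]12C` gives 35000 nM, and compound 3 `C=C/C(C)=C/[C@@H](OC(C)=O)[C@H]1C(=C)CC[C@@H]2[C@]1(C)CCC[C@@]2(C)C(=O)OC` gives 58300 nM. Compound 2 has the lowest of these three numbers, yet its gaps to both others lie within the scatter, so the three stand together. For the measured compounds named here, the only step between compounds differing in a single place, a 1.0-fold lower number from compound 1 to compound 2 (0.01 log units; within the scatter), concerns another part of the shared core and moved nothing beyond the scatter. Compound 4 `C=CC(=C)[C@@H](C[C@H]1C(=C)CC[C@@H]2[C@]1(C)CCC[C@@]2(C)C(=O)O)OO` differs from compound 2 by carboxy in place of hydroxymethyl on a saturated ring carbon. Going by the values given here, no measured step touches this position, so no shift beyond the scatter is expected. Compound 4 is therefore estimated at 35000 nM, between 15000 nM and 80000 nM, meaning a step of a 1.0-fold higher number from compound 2 to compound 4 (0.01 log units; within the scatter).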

Compound 4, concentration for 50% growth inhibition: 38000 nM
The estimate for compound 4 lay 1.1-fold (0.04 log units) below the measured number; measured number inside the range.
By their numbers in this assay, from the lowest: compounds 2, 1, 4 and 3 (each within the scatter of the next).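

For the compounds shown here, this is the first step measured at this saturated ring carbon: in this assay, a 1.1-fold higher number from compound 2 to compound 4 (0.04 log units; within the scatter). Carboxy in place of hydroxymethyl therefore leaves the growth-inhibition reading unchanged within the scatter, at least on the shared core of these two compounds. Nothing measured here bears on why this position tolerates the change.

From the compounds shown here alone, whether an amine or an amide on this same carbon would read the same remains open. So does whether carboxy in place of hydroxymethyl would give a similar result with the side chain of compound 1.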